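The source may hold more compounds than are shown below. What is called first, only, known or untested is meant among the compounds shown, and "the series" means these compounds.

Going by the values given here, compound 1 `COc1cccc(Cn2cc(-c3ccc(C)cc3)nn2)c1` is the one member of the set that gives a number: in a functional assay on B16 cells (Mus musculus) for cytotoxicity, read by MTT assay, with a stated time of 48 h (a higher number here means a weaker inhibitor, a lower number a stronger inhibitor), compound 1 gives 19500 nM. Compound 2 `COc1ccc(C(O)c2cn(Cc3cccc(OC)c3)nn2)cc1` reaches only a limit in this assay, > 100000 nM. Compound 3 `COc1ccc(C(O)c2cn(C[C@H]3COC(C)(C)O3)nn2)c(OC)c1OC` likewise stops at a limit in this assay, > 100000 nM. Among the compounds with values here, those two values are the limit of > 100000 nM in this assay, at which 2 of the 3 values shown sit, so compound 1 is the sole anchor for any step. Compound 4 `COc1cccc(Cn2cc(-c3ccc(C(F)(F)F)cc3)nn2)c1` differs from compound 1 in one place, (trifluoromethyl in place of methyl on an aromatic carbon). Within the data shown here, no step between two measured compounds is available to size this change, so a modest shift in either direction, or none beyond the scatter, is expected. For compound 4 the expected value in this assay is 15000 nM, within 5000 nM to 60000 nM. The step this estimate means is a 1.3-fold lower number from compound 1 to compound 4 (0.11 log units; within the scatter), expected to lie within the usual scatter.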

Compound 4, half-maximal inhibitory concentration: 17400 nM
Compound 4: middle estimate off by 1.2-fold (0.06 log units), on the low side; low and high end bracket the measured number.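

In this assay, the position para to a large group now has its first readable step: a 1.1-fold lower number from compound 1 to compound 4 (0.05 log units; within the scatter). Trifluoromethyl in place of methyl on this aromatic carbon therefore leaves the value within the scatter, and compound 4 joins compound 1 in giving a number rather than a limit. Nothing shown gives a cause for this step.

Going by these compounds, whether an amine, a carboxylic acid or a longer chain at this position would also keep a measurable value remains open. Steps involving compound 2 or compound 3, which stop at limits, cannot be read.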